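This account rests on a few compounds, and the source may have more. Where it says the series, first, only, none or still open, it means among the compounds named here.

Compound 1 `Cc1cc(NCc2ccccn2)n2ncc(-c3ccccc3F)c2n1`: 5000 nM
Compound 2 `Cc1cc(NCc2ccccn2)n2ncc(-c3ccccc3C)c2n1`: < 5000 nM, a limit

In a physicochemical assay for solubility, read by HPLC, using the shake flask method, measured as kinetic solubility, with a stated time of 2 h, at pH 7.4 (a lower number here means a less soluble compound, a higher number a more soluble compound), compound 1 gives 5000 nM. Compound 2 gives < 5000 nM in this assay, which is a limit of the assay and not a number. The step of a number no higher from compound 1 to compound 2 (the limit leaves the size open) is therefore of unreadable size; compound 2 sits at the limit (the limit of < 5000 nM in this assay, at which 1 of the 2 values shown sits). Compound 3 `Cc1cc(NCc2ccccn2)n2ncc(-c3ccncc3)c2n1` differs from compound 2 by pyridin-4-yl in place of 2-methylphenyl on an aromatic carbon. Among the compounds with values here, no measured step covers this exchange, so the direction is open and the guess rests on compound 2 alone. Compound 3 is expected at 5000 nM, in the range 1200 nM to 20000 nM. The estimated step of a number no lower from compound 2 to compound 3 (the limit leaves the size open) is expected to be small against the limit.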

Compound 3, solubility: 161000 nM
The estimate for compound 3 lay 32-fold (1.51 log units) below the measured number; the whole stated range lies below it.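

In this assay, pyridin-4-yl in place of 2-fluorophenyl at this aromatic carbon gives a 32-fold higher number from compound 1 to compound 3 (1.51 log units; beyond the scatter), so this position can carry a large change in the read-out, which the two carbon-only rings of compounds 1 and 2 did not show. The exchange from 2-methylphenyl gives an at least 32-fold higher number from compound 2 to compound 3 (1.50 log units; beyond the scatter). The value of compound 2 is a limit and not a number: the limit of < 5000 nM in this assay, at which 1 of the 3 values shown sits.

On these data alone, whether the step follows the ring nitrogen or the loss of the fluoro and methyl groups stays open. As far as these compounds go, how an unsubstituted phenyl or a pyridin-3-yl would read at this position also stays open.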